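The source may hold more compounds than are shown below. What is called first, only, known or untested is meant among the compounds shown, and "the series" means these compounds.

Working notes on the series in an assay on SK-BR-3 cells for inhibition of Aromatase (Homo sapiens); on this read-out higher numbers stand for weaker inhibition and lower numbers for stronger inhibition. Compound 1 `CS(=O)(=O)Nc1ccc([N+](=O)[O-])cc1OCc1ccc([N+](=O)[O-])cc1` gives 400 nM. For the measured compounds named here, compound 2 `CC(C)c1ccc(COc2cc([N+](=O)[O-])ccc2NS(C)(=O)=O)cc1` gives 7450 nM, the highest of the two numbers measured so far; the only step so far, a 19-fold higher number from compound 1 to compound 2 (1.27 log units; beyond the scatter), is large and lies beyond the scatter, so compound 2 stands well apart from compound 1 in this assay.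

Compound 3 `CS(=O)(=O)Nc1ccc([N+](=O)[O-])cc1OCc1ccc(F)cc1` is not yet measured. It differs from compound 2 by fluoro in place of isopropyl on an aromatic carbon. Going by the values given here, the one measured step bearing on this position, a 19-fold higher number from compound 1 to compound 2 (1.27 log units; beyond the scatter), shows that exchanging the group at this carbon can move the number a long way. With fluoro in place of isopropyl, the step from compound 2 to compound 3 is expected to run back toward compound 1, though how far is uncertain: the estimated step is a 5.0-fold lower number from compound 2 to compound 3 (0.70 log units; beyond the scatter). For compound 3 the estimate in this assay is 1500 nM, with a range from 400 nM to 6000 nM.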

Compound 3, half-maximal inhibitory concentration: 580 nM
Compound 3: the middle estimate sits 2.6-fold (0.41 log units) above what was measured; the range from low to high includes it.
By their numbers in this assay, from the lowest: compounds 1 and 3 (each within the scatter of the next); then compound 2.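

In this assay, the step of a 13-fold lower number from compound 2 to compound 3 (1.11 log units; beyond the scatter) shows that the high number of compound 2 is not a property of the shared core: with fluoro on this aromatic carbon, para to a large group, the number returns to the level of compound 1. The step of a 1.5-fold higher number from compound 1 to compound 3 (0.16 log units; within the scatter) stays within the scatter, so fluoro and nitro cannot be told apart at this position, although the two groups are quite different, and among the three groups shown only isopropyl stands apart. No measured evidence on why this change acts as it does is at hand.

The compounds shown leave open whether a methyl, a methoxy, an amine or a carboxylic acid on this carbon would fall with fluoro and nitro or with isopropyl. They also leave open whether a group of intermediate length, such as an ethyl, would give an intermediate number.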